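Tail amine variation on the shared core

This account rests on a few compounds, and the source may have more. Where it says the series, first, only, none or still open, it means among the compounds named here.

The series keeps one core and varies the amine at the end of the chain. Compound 1 `CCN(CC)CCN(C)c1ccc(Cn2c(=O)[nH]c3c(N)nc(C(F)(F)F)cc32)cn1` gives 2.5 10^-6 cm/s in an ADME assay for permeability, using PAMPA; on this read-out higher numbers stand for higher permeability and lower numbers for lower permeability. Compound 2 `CN(CCN1CCCCC1)c1ccc(Cn2c(=O)[nH]c3c(N)nc(C(F)(F)F)cc32)cn1` gives 5.2 10^-6 cm/s in this assay, and compound 3 `CN1CCN(CCN(C)c2ccc(Cn3c(=O)[nH]c4c(N)nc(C(F)(F)F)cc43)cn2)CC1` gives 0.7 10^-6 cm/s. Compound 3 thus stands lowest of the three measured values: a 3.6-fold lower number from compound 1 to compound 3 (0.55 log units; beyond the scatter) and a 7.4-fold lower number from compound 2 to compound 3 (0.87 log units; beyond the scatter), both beyond the scatter, while a 2.1-fold higher number from compound 1 to compound 2 (0.32 log units; beyond the scatter) is the smaller step.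

Compound 4 `CN(C)CCN(C)c1ccc(Cn2c(=O)[nH]c3c(N)nc(C(F)(F)F)cc32)cn1` is not yet measured. The change from compound 3 is dimethylamino in place of 4-methylpiperazin-1-yl on a saturated chain carbon, two bonds along the chain from a nitrogen on an aromatic ring. Within the data shown here, the steps that bear on it run the other way round: a 3.6-fold lower number from compound 1 to compound 3 (0.55 log units; beyond the scatter) and a 7.4-fold lower number from compound 2 to compound 3 (0.87 log units; beyond the scatter) both show a modest rise whenever 4-methylpiperazin-1-yl is exchanged for a dialkylamino. Compound 1, with 2.5 10^-6 cm/s, carries diethylamino, the nearest measured analogue of dimethylamino. A rise of roughly that size is therefore expected for compound 4, a 2.9-fold higher number from compound 3 to compound 4 (0.46 log units; beyond the scatter). The estimate for compound 4 is 2 10^-6 cm/s, with a range from 1 10^-6 cm/s to 4 10^-6 cm/s.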

Compound 4, apparent permeability: 0.9 10^-6 cm/s
Compound 4: middle estimate off by 2.2-fold (0.35 log units), on the high side; measured number outside the range, below it.
By their numbers in this assay, from the lowest: compounds 3 and 4 (each within the scatter of the next); then compound 1; then compound 2.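

Leaving the ring does not on its own separate the tail amines in this assay: a 1.3-fold higher number from compound 3 to compound 4 (0.11 log units; within the scatter), so dimethylamino and 4-methylpiperazin-1-yl cannot be told apart at this position on the chain. The earlier gain on moving away from 4-methylpiperazin-1-yl therefore does not extend to every dialkylamino, since a 2.8-fold lower number from compound 1 to compound 4 (0.44 log units; beyond the scatter) and a 5.8-fold lower number from compound 2 to compound 4 (0.76 log units; beyond the scatter) place diethylamino and piperidin-1-yl clearly apart from dimethylamino. No measurement in hand explains these differences between the tail amines.

Still open, on these data alone, is where a pyrrolidin-1-yl or morpholin-4-yl tail would fall relative to these compounds. Also open, as far as these compounds go, is whether the same order of tail amines would hold with a longer chain in place of the ethyl link.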